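The source may report more compounds than this note shows. Statements on the series, on what has been measured and on what is new or still open speak of the compounds shown alone.

In a functional assay on SNB-75 cells (Homo sapiens) for inhibition (a lower number here means a stronger inhibitor of growth, a higher number a weaker inhibitor of growth), compound 1 `CC(=O)CC/C=C(\C)CCC1=C(C)CCCC1(C)C` gives 5150 nM and compound 2 `C=C1CCC[C@H]2[C@](C)(CCC(C)=O)[C@@H](C)CC[C@]12C` gives 3020 nM. Compound 3 `CC1=C(CC/C(C)=C/CC[C@@]2(C)CC[C@@H]([C@H](C)C(=O)O)OO2)C(C)(C)CCC1` reaches only the limit of > 100000 nM in this assay, so no number is known for it. Compound 4 `CC1=C(CC/C(C)=C/CC[C@@]2(C)CC[C@H]([C@H](C)C(=O)O)OO2)C(C)(C)CCC1` is the next member of the series. (the two compounds have the same atoms and bonds and differ only in configuration as drawn: 1 of 4 stereo elements differ; a stereocentre at a saturated ring carbon is drawn S in compound 3 and R in compound 4). Within the data shown here, no step between measured compounds is available to size a change of this kind. Compound 3 sits at the limit of > 100000 nM in this assay, at which 1 of the 3 values shown sits, and a change of configuration alone is not expected to move the value beyond the scatter in this assay, so compound 4 is expected to stay near the limit as well. The estimate for compound 4 in this assay is 100000 nM, between 30000 nM and 300000 nM. The expected step is a number no higher from compound 3 to compound 4 (the limit leaves the size open), none beyond the scatter.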

Compound 4, concentration for 50% growth inhibition: > 5000 nM
Compound 4 was reported as a limit; the forecaster's own chance of this, stated with the estimate: 75%; the middle value lies beyond the limit too.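

Among these compounds, compound 3 and compound 4 are both reported only as limits in this assay, so no step between them can be read. From the compounds shown here alone, whether the change of configuration at the saturated ring carbon alters growth inhibition stays open.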